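Working notes: side-chain amines, compound 3 to compound 4

The compounds below may be only part of what the source reports. "The series", "measured", "known", "first", "only" and "open" are said of these compounds alone.

Measured in a functional assay on MDA-MB-231 cells (Homo sapiens) for cytotoxicity, read by MTT assay, with a stated time of 72 h; on this read-out lower numbers stand for stronger inhibition and higher numbers for weaker inhibition:
- compound 1 `CN1CCN(CCCn2c3c(c4ccccc42)C(=O)c2c[n+]([O-])c4ccccc4c2C3=O)CC1`: 390 nM
- compound 2 `O=C1c2c[n+]([O-])c3ccccc3c2C(=O)c2c1c1ccccc1n2CCN1CCCCC1`: 1050 nM
- compound 3 `CN1CCN(CCCCCCn2c3c(c4ccccc42)C(=O)c2c[n+]([O-])c4ccccc4c2C3=O)CC1`: 2400 nM

Compound 3 has the highest number of the three. The nearest measured step is a 2.3-fold higher number from compound 2 to compound 3 (0.36 log units; beyond the scatter), and the furthest is a 6.2-fold higher number from compound 1 to compound 3 (0.79 log units; beyond the scatter).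

The move to compound 4 `CN(C)CCCCn1c2c(c3ccccc31)C(=O)c1c[n+]([O-])c3ccccc3c1C2=O` is dimethylamino in place of 2-(4-methylpiperazin-1-yl)ethyl on a saturated chain carbon, four bonds along the chain from an aromatic nitrogen. It places dimethylamino where 2-(4-methylpiperazin-1-yl)ethyl stood, four bonds along the chain from an aromatic nitrogen.

For the measured compounds named here, no measured step makes this exact change. The nearest guides are the two modest steps above, along with a 2.7-fold higher number from compound 1 to compound 2 (0.43 log units; beyond the scatter). A modest step to a lower number is expected in this assay, though the direction is uncertain.

The expected change is a 2.5-fold lower number from compound 3 to compound 4 (0.40 log units; beyond the scatter).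

For compound 4 the estimated value is 950 nM, with an expected range from 350 nM to 2600 nM.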

Compound 4, half-maximal inhibitory concentration: 350 nM
For compound 4 the middle estimate is 2.7-fold (0.43 log units) above the measured one; the measured number falls inside the stated range.
By their numbers in this assay, from the lowest: compounds 4 and 1 (each within the scatter of the next); then compound 2; then compound 3.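

In this assay the change to dimethylamino gives a 6.9-fold lower number from compound 3 to compound 4 (0.84 log units; beyond the scatter) and shows that the high number of compound 3 does not extend to every amine on a longer chain. The same comparison with a shorter side chain gives a 3.0-fold lower number from compound 2 to compound 4 (0.48 log units; beyond the scatter) while a 1.1-fold lower number from compound 1 to compound 4 (0.05 log units; within the scatter) stays within the scatter, so this read-out does not separate these two side chains. No evidence here accounts for these differences. Chain and amine change together in these steps, so dimethylamino on a longer chain and 4-methylpiperazin-1-yl on the chain of compound 4 would separate the two, and a morpholine remains open.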